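A few compounds are considered here, and "the series" means these few. Any claim that something is new, unique, unknown or untested is made for them only; others in the source may bear on it.

Measured compounds in the series:

- compound 1, `COc1ccc(C(=O)c2sc3nc(-c4cccs4)ccc3c2N)c(OC)c1`: 0.52 ug/mL
- compound 2, `CCOC(=O)c1sc2nc(-c3cccs3)ccc2c1N`: > 4 ug/mL
- compound 3, `Nc1c(C(=O)c2cccc([N+](=O)[O-])c2)sc2nc(-c3cccs3)ccc12`: 0.15 ug/mL

For the measured compounds named here, in a functional assay on WI-38 VA13 cells (Homo sapiens) for cytotoxicity (a lower number here means that less compound is needed, a higher number that more compound is needed for the effect), compound 2 gives only a limit, > 4 ug/mL, and no number; it is the one value of the three that sits at the limit of > 4 ug/mL in this assay, at which 1 of the 3 values shown sits. Compound 1 gives 0.52 ug/mL in this assay, and compound 3 gives 0.15 ug/mL, both numbers well inside the measured window. Going by the values given here, no step between measured compounds differing in a single place is available, so the gap between compound 2 and the other two can only be read from their values as they stand.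

Compound 4, `Nc1c(C(=O)c2ccc(F)c(F)c2)sc2nc(-c3cccs3)ccc12`, has not yet been measured. It differs from compound 2 by 3,4-difluorophenyl in place of ethoxy on a carbonyl carbon. Compound 1 and compound 3 also carry a substituted aromatic ring on that carbonyl carbon, and both give numbers rather than limits in this assay; on that basis compound 4 is expected to land among them rather than at the limit. The step from compound 2 to compound 4 is expected to be a decrease in the number well beyond the scatter, an at least 13-fold lower number from compound 2 to compound 4 (1.12 log units; beyond the scatter). The estimate for compound 4 in this assay is 0.3 ug/mL, with a range from 0.1 ug/mL to 1 ug/mL.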

Compound 4, half-maximal effective concentration: > 4 ug/mL
Compound 4 was reported as a limit (the forecaster's own chance of this, stated with the estimate: 10%); at least 13-fold (1.12 log units) between middle value and limit.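

In this assay compound 4 gives > 4 ug/mL, a limit and not a number. For the compounds shown here, compound 2 also gives only a limit, so no step between compound 2 and compound 4 can be read. The compounds shown leave open whether 3,4-difluorophenyl in place of ethoxy on a carbonyl carbon changes the value at all, and by how much.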